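A few compounds are considered here, and "the series" means these few. Any claim that something is new, unique, unknown or untested is made for them only; others in the source may bear on it.

Measured compounds in a functional assay on the whole organism (strain albino) with Rattus norvegicus as the target, in the maximal electroshock model, with a stated time of 1 h, at a dose of 30 mg/kg by the intraperitoneal route; a lower number here means less inhibition, a higher number more inhibition at the dose given (going by the name of the read-out):

compound 1 `COc1cccc(C2SCC(=O)N2c2nnc(CNn3c(C)nc4ccccc4c3=O)s2)c1`, 60%
compound 2 `Cc1nc2ccccc2c(=O)n1NCc1nnc(N2C(=O)CSC2c2ccc(O)cc2)s1`, 60%
compound 3 `Cc1nc2ccccc2c(=O)n1NCc1nnc(N2C(=O)CSC2c2ccc(N(C)C)cc2)s1`, 60%

Compound 3 stands level with compounds 1 and 2 in this assay; its nearest neighbour is compound 1 and its furthest is compound 2, and neither gap reaches beyond the scatter. Compound 4 `COc1cc(C2SCC(=O)N2c2nnc(CNn3c(C)nc4ccccc4c3=O)s2)ccc1O` is not yet measured. Its difference from compound 3 is 4-hydroxy-3-methoxyphenyl in place of 4-(dimethylamino)phenyl on a saturated ring carbon.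

Going by the values given here, three measured steps bear on this change, all at the same saturated ring carbon of the shared core: no change at the digits printed from compound 1 to compound 2 (within the scatter), no change at the digits printed from compound 1 to compound 3 (within the scatter) and no change at the digits printed from compound 2 to compound 3 (within the scatter). Each of these swaps one aromatic group for another at that position, including the removal of a hydroxy group and the introduction of a dimethylamino group, and none moved the read-out beyond the scatter. The step to compound 4 again exchanges one aromatic group for another at that same carbon, so no step beyond the scatter is expected in this assay, in either direction.

Compound 4 is therefore expected to give 60% in this assay, with a range from 45% to 75%. The expected step is no change at the digits printed from compound 3 to compound 4 (within the scatter).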

Compound 4, a percentage reported as inhibition, in the whole organism at one dose (the size of the read-out at that dose, not a potency): 60%
Compound 4: middle estimate and measured number agree at the digits printed; measured number inside the range.
By their numbers in this assay, from the lowest: compounds 1, 2, 3 and 4 (each within the scatter of the next).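

In this assay, compound 4 is the first shown with two oxygen substituents on the aromatic ring at the saturated ring carbon: adding methoxy to the ring of compound 2 gives no change at the digits printed from compound 2 to compound 4 (within the scatter), and adding hydroxy to the ring of compound 1 gives no change at the digits printed from compound 1 to compound 4 (within the scatter). Going by these compounds alone, the exchange of 4-(dimethylamino)phenyl for 4-hydroxy-3-methoxyphenyl gives no change at the digits printed from compound 3 to compound 4 (within the scatter), so a second ring substituent at this position, in this single-dose read-out, separates no compound from the others. No measurement available here accounts for this flat result.

Going by these compounds, whether the read-out stays level with a carboxylic acid on the aromatic ring, or with a longer alkyl chain in place of the ring, remains open. Any differences among these four compounds at other doses also remain open.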